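The source may hold more compounds than are shown below. What is called first, only, known or untested is meant among the compounds shown, and "the series" means these compounds.

Three compounds share one core and differ only in the groups that hang from the urea end of the molecule. Compound 1 `O=C(Nc1cccc(-n2cc(-c3ccncc3)c(-c3cc(O)cc(Cl)c3)n2)c1)Nc1ccc(Cl)c(C(F)(F)F)c1` gives 100% in a functional assay on MOLT-4 cells (Homo sapiens) for inhibition, read by sulforhodamine B assay, with a stated time of 48 h, tested at 0.01 uM; a lower number here means a stronger effect, a higher number a weaker effect of the compound at the concentration tested. Compound 2 `O=C(Nc1cccc(-n2cc(-c3ccncc3)c(-c3cc(O)cc(Cl)c3)n2)c1)Nc1ccc(Cl)c(Cl)c1` gives 93% in this assay, and the single step shown between measured compounds, a number 7 percentage points lower from compound 1 to compound 2 (within the scatter), therefore means no real change. Compound 3 `COc1cc(Cl)cc(-c2nn(-c3cccc(NC(=O)Nc4cc(C(F)(F)F)cc(C(F)(F)F)c4)c3)cc2-c2ccncc2)c1` gives 94% in this assay; this stands second of the three numbers, within the scatter of compound 2 and also within the scatter of compound 1, so all three numbers are effectively alike.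

Compound 4 `COc1cc(Cl)cc(-c2nn(-c3cccc(NC(=O)Nc4cccc(C(F)(F)F)c4)c3)cc2-c2ccncc2)c1` has not been measured. It differs from compound 3 in one place: hydrogen in place of trifluoromethyl on an aromatic carbon. Among the compounds with values here, only one measured step bears on this, the swap at a similar aromatic carbon a number 7 percentage points lower from compound 1 to compound 2 (within the scatter), which stayed within the scatter. Within the data shown here, no measured step removes a trifluoromethyl altogether, so the evidence is thin. Still, no step beyond the scatter is expected, a number 2 percentage points higher from compound 3 to compound 4 (within the scatter). Compound 4 is therefore estimated at 96%, between 84% and 106%.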

Compound 4, a percentage reported as activity, at one concentration (the size of the read-out at that concentration, not a potency): 95%
Compound 4: middle estimate off by 1 percentage points, on the high side; low and high end bracket the measured number.
By their numbers in this assay, from the lowest: compounds 2, 3, 4 and 1 (each within the scatter of the next).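

Hydrogen in place of trifluoromethyl, on an aromatic carbon meta to a trifluoromethyl group, gives a number 1 percentage points higher from compound 3 to compound 4 (within the scatter) in this assay. The earlier step only put chloro in place of trifluoromethyl at a similar carbon, whereas here 4 heavy atoms leave and no heavy atom enters, and the numbers for the two compounds are still alike. Nothing measured on these compounds explains this likeness.

The compounds shown leave open whether an amine or a carboxylic acid on this aromatic carbon would read alike, and whether the remaining trifluoromethyl could also give way to hydrogen with the same outcome. Each number also comes from a single concentration, so any difference in potency among these compounds remains unseen.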